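Moving a Fluorine on Two Related Cores

The source may hold more compounds than are shown below. What is called first, only, known or untested is meant among the compounds shown, and "the series" means these compounds.

Compound 1 `Cc1nc(-c2ccc(F)cc2)c(C(=O)N2CCN(c3cccc(Cl)c3)CC2)o1`: 40.1 nM
Compound 2 `Cc1nc(-c2cccc(F)c2)c(C(=O)N2CCN(c3cccc(Cl)c3)CC2)o1`: 33.7 nM
Compound 3 `COc1cc(OC)cc(N2CCN(C(=O)c3onc(C)c3-c3cccc(F)c3)CC2)c1`: 152 nM

In a functional assay on HL-60 cells (Homo sapiens) for inhibition, read by MTT assay, with a stated time of 72 h (a higher number here means a weaker inhibitor, a lower number a stronger inhibitor), compound 3 gives the highest of the three numbers. Compared with compound 2 its core is built differently, but the difference between the two cores is not broken down here. Compound 4 `COc1cc(OC)cc(N2CCN(C(=O)c3onc(C)c3-c3ccc(F)cc3)CC2)c1` carries the change 4-fluorophenyl in place of 3-fluorophenyl on an aromatic carbon on the core of compound 3. The same kind of change 4-fluorophenyl in place of 3-fluorophenyl on an aromatic carbon on the core of compound 2 gave a 1.2-fold higher number from compound 2 to compound 1 (0.08 log units; within the scatter); the two places are not identical, since in compound 2 the aromatic carbon lies next to the ring nitrogen, whereas in compound 3 it lies next to the ring atom that bears a methyl group. On that basis compound 4 is expected to show a 1.2-fold higher number from compound 3 to compound 4 (0.07 log units; within the scatter) in this assay, a small move, because of a 1.2-fold higher number from compound 2 to compound 1 (0.08 log units; within the scatter). The estimate for compound 4 is 180 nM, between 80 nM and 400 nM.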

Compound 4, half-maximal inhibitory concentration: 475 nM
Beside the measured number, compound 4's estimate is 2.6-fold (0.42 log units) below it; the whole stated range lies below it.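

In this assay, 4-fluorophenyl in place of 3-fluorophenyl on the core of compound 3 gave a 3.1-fold higher number from compound 3 to compound 4 (0.49 log units; beyond the scatter). Although this step lies beyond the scatter and the one on the other core does not, the two steps cannot be told apart: the same change on two cores in this assay, a 1.2-fold higher number (0.08 log units; within the scatter) from compound 2 to compound 1 and a 3.1-fold higher number (0.49 log units; beyond the scatter) from compound 3 to compound 4, 2.6-fold (0.42 log units) apart, within the scatter of two such steps The pair therefore shows no demonstrated dependence of this change on the core, but with one step on each core, it does not show that the change carries over reliably or that one step predicts the size of the other.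

The compounds shown leave open how the fluorophenyl position would behave with a nitrile or an amine in place of the fluorine. They also leave open which part of the difference between the two cores matters for this change.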